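The source may report more compounds than this note shows. Statements on the series, on what has been measured and on what is new or still open speak of the compounds shown alone.

Compound 1 `NC(=O)CC[C@H](NC(=O)CN(c1ncnc2c1ncn2C1CCCCO1)C1CC1)C(=O)OCc1ccccc1` and compound 2 `O=C(CN(c1ncnc2c1ncn2C1CCCCO1)C1CC1)N[C@@H](CCC(=O)OCc1ccccc1)C(=O)OCc1ccccc1` share one core and differ only at a carbonyl carbon, where an amino group in compound 1 is replaced by a benzyloxy group in compound 2. In a functional assay on the whole organism (Tail, strain ICR) with Mus musculus as the target, in the tail flick test, with a stated time of 120 min, at a dose of 25 umol/kg by the oral route (a lower number here means a weaker effect, a higher number a stronger effect of the compound at the dose given), compound 1 gives 22.3%, and in this assay compound 2 gives 20.7%; the step of a number 1.6 percentage points lower from compound 1 to compound 2 (within the scatter) lies within the scatter, so compound 2 stands in the same place as compound 1 and neither can be set apart from the other.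

Compound 3 `O=C(CN(c1ncnc2c1ncn2C1CCCCO1)C1CC1)NCC(=O)OCc1ccccc1` differs from compound 2 by hydrogen in place of 2-(benzyloxycarbonyl)ethyl on a saturated chain carbon bound to an amide-type nitrogen and a carbonyl carbon. Among the compounds with values here, no measured step touches this part of the molecule: the only step, a number 1.6 percentage points lower from compound 1 to compound 2 (within the scatter), concerned a group on a carbonyl carbon and was within the scatter. Without any guide, the expected step is a number 0.7 percentage points lower from compound 2 to compound 3 (within the scatter), no change beyond the scatter. Compound 3 is therefore estimated at 20%, with a range from 5% to 38%.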

Compound 3, a percentage reported as activity, at one dose (the size of the read-out at that dose, not a potency): 17.2%
Estimate against measurement, compound 3: 2.8 percentage points above; the measured number falls inside the stated range.
By their numbers in this assay, from the lowest: compounds 3, 2 and 1 (each within the scatter of the next).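

Removing the side chain from the saturated chain carbon bound to an amide-type nitrogen and a carbonyl carbon leaves the read-out in this assay within the scatter: the step is a number 3.5 percentage points lower from compound 2 to compound 3 (within the scatter) on losing 2-(benzyloxycarbonyl)ethyl, and a number 5.1 percentage points lower from compound 1 to compound 3 (within the scatter) on losing 2-carbamoylethyl. Compound 3, with only hydrogen at this place, therefore cannot be set apart from compound 1 or compound 2, and neither group is shown to be needed for the effect seen at this dose. No measurement is at hand that would explain this result.

Going by these compounds, whether a different group at this place, such as an amine on a longer chain, would move the number beyond the scatter remains open. On these data alone, whether a carboxylic acid in place of the benzyl ester shared by all three compounds would matter also remains open.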